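Swapping an aminophenyl for a dimethoxyphenyl on the ketone

This account rests on a few compounds, and the source may have more. Where it says the series, first, only, none or still open, it means among the compounds named here.

Compound 1 `COc1cc(-c2cc(/C=C/C(=O)c3ccc(N)cc3)[nH]n2)cc(OC)c1OC`: 99%
Compound 2 `COc1ccc(-c2cc(/C=C/C(=O)c3ccc(N)cc3)[nH]n2)cc1OC`: 100%
Compound 3 `COc1ccc(-c2cc(/C=C/C(=O)c3cc(OC)c(OC)c(OC)c3)[nH]n2)cc1OC`: 99%

All three measured compounds were tested in a functional assay on SF-268 cells (Homo sapiens) for cytotoxicity, read by sulforhodamine B assay, with a stated time of 48 h, tested at 0.01 uM; on this read-out higher numbers stand for a weaker effect at the one concentration tested and lower numbers for a stronger effect. In this assay compound 1 gives 99%, compound 2 gives 100% and compound 3 gives 99%. Compound 1 stands level with compound 3 at the digits shown, the two together being the lowest of the three numbers, and the only measured step, a number 1 percentage points higher from compound 1 to compound 2 (within the scatter), lies within the scatter. In short, every measured compound leaves the cells almost untouched at this concentration, and no change tried so far has moved the read-out.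

Compound 4 `COc1ccc(C(=O)/C=C/c2cc(-c3cc(OC)c(OC)c(OC)c3)n[nH]2)cc1OC` has not yet been measured. It differs from compound 1 in one place: 3,4-dimethoxyphenyl in place of 4-aminophenyl on a carbonyl carbon. For the measured compounds named here, no measured step bears on this exact change; the step from compound 1 to compound 2 concerns a different ring, and the pair of compound 1 and compound 3 differs at the same carbonyl carbon but with another group entering, and those two values sit level. Nothing here points to a change beyond the scatter, so a step of no change at the digits printed from compound 1 to compound 4 (within the scatter) is expected to stay within it. Compound 4 is therefore estimated at 99%, in the range 92% to 103%.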

Compound 4, a percentage reported as activity, at one concentration (the size of the read-out at that concentration, not a potency): 93%
Beside the measured number, compound 4's estimate is 6 percentage points above it; measured number inside the range.
By their numbers in this assay, from the lowest: compounds 4, 1, 3 and 2 (each within the scatter of the next).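

In this assay, placing 3,4-dimethoxyphenyl where 4-aminophenyl stood on the carbonyl carbon gives a number 6 percentage points lower from compound 1 to compound 4 (within the scatter), so this larger group leaves the read-out within its usual scatter. For the compounds shown here, the only earlier step concerned a different ring, which makes this the first direct test of the carbonyl position, and it shows that the read-out at this one concentration does not depend on keeping the 4-aminophenyl group there. Since the cells remain nearly untouched across all the compounds, this single reading cannot separate the two groups, and nothing measured here offers an explanation for the small gap that is printed.

On these data alone, it remains open whether a quite different group on the same carbonyl carbon, such as an unsubstituted phenyl, a 4-carboxyphenyl or a straight alkyl chain, would also leave the read-out unmoved. The compounds shown also leave open whether 3,4-dimethoxyphenyl and 4-aminophenyl would still sit within the scatter of each other at a higher concentration, where the cells might respond more clearly.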